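A few compounds are considered here, and "the series" means these few. Any claim that something is new, unique, unknown or untested is made for them only; others in the source may bear on it.

Of the compounds shown here, three have been measured in a functional assay on NCI/ADR-RES cells (Homo sapiens) for cytotoxicity, read by sulforhodamine B assay, with a stated time of 48 h; a higher number here means a weaker inhibitor of growth, a lower number a stronger inhibitor of growth. Compound 1 `ClCc1ccc(Cn2cnc3c(Cl)ncnc32)cc1` gives 5490 nM. Compound 2 `ClCc1cccc(Cn2cnc3ncnc(Cl)c32)c1` gives 9770 nM. Compound 3 `ClCc1ccc(Cn2cnc3c(Cl)nc(Cl)nc32)cc1` gives > 100000 nM, which is a limit of the assay rather than a number, namely (the limit of > 100000 nM in this assay, at which 1 of the 3 values shown sits).

Compound 3 arises from compound 1 by one change, (chloro in place of hydrogen on an aromatic carbon), and that change produced an at least 18-fold higher number from compound 1 to compound 3 (1.26 log units; beyond the scatter). Compounds 1 and 2 are built from the same atoms joined differently; the difference between the two cores is not broken down here, and their two values lie within the usual scatter of each other. Compound 4 `ClCc1cccc(Cn2cnc3nc(Cl)nc(Cl)c32)c1` has not yet been measured; it arises from compound 2 by the same change, (chloro in place of hydrogen on an aromatic carbon). Because of an at least 18-fold higher number from compound 1 to compound 3 (1.26 log units; beyond the scatter), a step of similar size, a 15-fold higher number from compound 2 to compound 4 (1.19 log units; beyond the scatter), is expected in this assay. Compound 4 is accordingly estimated at 150000 nM, with a range from 30000 nM to 600000 nM, and a result reported only as a limit would not surprise.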

Compound 4, concentration for total growth inhibition: 3090 nM
For compound 4 the middle estimate is 49-fold (1.69 log units) above the measured one; the measured number lies below the stated range.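

In this assay the chloro in place of hydrogen gave a 3.2-fold lower number from compound 2 to compound 4 (0.50 log units; beyond the scatter) and so ran opposite to the earlier step, and the two steps differ: the same change on two cores in this assay, an at least 18-fold higher number (1.26 log units; beyond the scatter) from compound 1 to compound 3 and a 3.2-fold lower number (0.50 log units; beyond the scatter) from compound 2 to compound 4, at least 57-fold (1.76 log units) apart, beyond the scatter of two such steps. The change therefore did not carry from one core to the other in this series, although two pairs do not show which feature of the cores sets its direction. Compound 3 is reported only as a limit, so the earlier step has no fixed size: the limit of > 100000 nM in this assay, at which 1 of the 4 values shown sits.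

The compounds shown leave open whether an amine or a methoxy group in that place, between two ring nitrogen atoms, would also differ between the two cores. They also leave open whether a longer chain in place of the chloromethyl group would alter the contrast.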